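This account rests on a few compounds, and the source may have more. Where it says the series, first, only, none or still open, it means among the compounds named here.

Compounds measured in a functional assay on 143B cells (Homo sapiens) for antiproliferative activity, read by MTT assay, with a stated time of 48 h; a higher number here means a weaker inhibitor, a lower number a stronger inhibitor:
- compound 1 `O=C(Nc1cccc(/C=C/C(=O)c2nc3ccccc3[nH]2)c1)c1cccc(Cl)c1` gives 3370 nM
- compound 2 `O=C(Nc1cccc(/C=C/C(=O)c2nc3ccccc3[nH]2)c1)c1ccc(Cl)cc1` gives 7440 nM
- compound 3 `O=C(Nc1cccc(/C=C/C(=O)c2nc3ccccc3[nH]2)c1)c1cccc(Br)c1` gives 4620 nM

Compound 3 stands second highest of the three numbers in this assay; the steps that lead to it are a 1.4-fold higher number from compound 1 to compound 3 (0.14 log units; within the scatter) and a 1.6-fold lower number from compound 2 to compound 3 (0.21 log units; within the scatter), so neither separates it from its neighbours. Compound 4 `O=C(Nc1cccc(/C=C/C(=O)c2nc3ccccc3[nH]2)c1)c1ccc(Br)cc1` has not been measured. It differs from compound 3 only in the position of the bromine: 4-bromophenyl in place of 3-bromophenyl on a carbonyl carbon. Among the compounds with values here, the one measured step of the same kind is a 2.2-fold higher number from compound 1 to compound 2 (0.34 log units; beyond the scatter), a modest rise beyond the scatter. Compound 4 is therefore expected to give a higher number than compound 3 by a similar amount, a 2.1-fold higher number from compound 3 to compound 4 (0.31 log units; beyond the scatter). Compound 4 is estimated at 9500 nM, with a range from 4500 nM to 20000 nM.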

Compound 4, half-maximal inhibitory concentration: 7310 nM
Compound 4: the middle estimate sits 1.3-fold (0.11 log units) above what was measured; the measured number falls inside the stated range.
By their numbers in this assay, from the lowest: compounds 1, 3, 4 and 2 (each within the scatter of the next, the first and the last beyond it).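

Exchanging 3-bromophenyl for 4-bromophenyl brings a 1.6-fold higher number from compound 3 to compound 4 (0.20 log units; within the scatter), so among the bromo compounds this change of position does not separate the pair, although the same change among the chloro compounds went beyond the scatter. The two ends of the comparison still differ, with a 2.2-fold higher number from compound 1 to compound 4 (0.34 log units; beyond the scatter). Bromo in place of chloro on the 4-substituted ring brings a 1.0-fold lower number from compound 2 to compound 4 (0.01 log units; within the scatter), and the halogen exchange reads the same on both placements: the same change on two cores in this assay, a 1.4-fold higher number (0.14 log units; within the scatter) from compound 1 to compound 3 and a 1.0-fold lower number (0.01 log units; within the scatter) from compound 2 to compound 4, 1.4-fold (0.14 log units) apart, within the scatter of two such steps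

What the compounds shown leave open is whether a methoxy group or an amine in place of the halogen would shift the number.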